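The compounds below may be only part of what the source reports. "The series", "measured", "known", "first", "only" and "open" are said of these compounds alone.

Compound 1 `COc1ccc(NC(=O)N2N=C(c3cc4ccccc4o3)CC2c2ccc(O)c(OC)c2)cc1` gives 29000000 nM in a functional assay on microsomes from liver (Rattus norvegicus, strain Wistar) for inhibition, with a stated time of 15 min; a higher number here means a weaker inhibitor, a lower number a stronger inhibitor. Compound 2 `COc1cc(C2CC(c3cc4ccccc4o3)=NN2C(=O)Nc2cccc(O)c2)ccc1O` gives 24000000 nM. Compound 3 `COc1cc(NC(=O)N2N=C(c3cc4ccccc4o3)CC2c2ccc(O)c(OC)c2)ccc1O` gives 12000000 nM.

Compound 2 stands second highest among the three numbers in this assay: its nearest neighbour is compound 1, which gives 29000000 nM, and the step of a 1.2-fold lower number from compound 1 to compound 2 (0.08 log units; within the scatter) lies within the scatter. Its furthest neighbour is compound 3, and the step of a 2.0-fold lower number from compound 2 to compound 3 (0.30 log units; within the scatter) also stays within the scatter. Among the compounds with values here, only the step of a 2.4-fold lower number from compound 1 to compound 3 (0.38 log units; beyond the scatter) reaches beyond it, and that step is modest.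

Compound 4 `COc1cc(C2CC(c3cc4ccccc4o3)=NN2C(=O)Nc2ccc([N+](=O)[O-])cc2)ccc1O` differs from compound 2 in the group on the amide-type nitrogen: 4-nitrophenyl in place of 3-hydroxyphenyl on an amide-type nitrogen. Within the data shown here, no measured pair shows 4-nitrophenyl in this place, so the three measured steps bear on it only in that every exchange of the group on the amide-type nitrogen so far has moved the number little. The account therefore expects no step beyond the scatter in this assay, with no particular direction.

Compound 4 is estimated at 22000000 nM, with a range from 8000000 nM to 55000000 nM, which means an expected step of a 1.1-fold lower number from compound 2 to compound 4 (0.04 log units; within the scatter).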

Compound 4, half-maximal inhibitory concentration: 113000000 nM
Compound 4: the middle estimate sits 5.1-fold (0.71 log units) below what was measured; measured number outside the range, above it.
By their numbers in this assay, from the lowest: compounds 3, 2 and 1 (each within the scatter of the next, the first and the last beyond it); then compound 4.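

In this assay, the group on the amide-type nitrogen no longer looks like a place where exchanges barely move the number: 4-nitrophenyl in place of 3-hydroxyphenyl gives a 4.7-fold higher number from compound 2 to compound 4 (0.67 log units; beyond the scatter), and 4-nitrophenyl in place of 4-hydroxy-3-methoxyphenyl gives a 9.4-fold higher number from compound 3 to compound 4 (0.97 log units; beyond the scatter), which makes compound 4 the weakest inhibitor of the four, although each step is modest. Loss of the hydroxyl alone does not account for this rise, since compound 1 also has no hydroxyl on this ring and nitro in place of methoxy on an aromatic carbon still gives a 3.9-fold higher number from compound 1 to compound 4 (0.59 log units; beyond the scatter). No measurement at hand explains why the number rises with this group.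

On these data alone, it remains open whether the rise belongs to the nitro group itself or would also appear with an amine, a carboxylic acid or a nitrile on the same phenyl ring. As far as these compounds go, it is also open whether 3-nitrophenyl would behave like 4-nitrophenyl, and whether the step would keep its size on a core other than the shared one.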